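A few compounds are considered here, and "the series" means these few. Any claim that something is new, unique, unknown or untested is made for them only; others in the source may bear on it.

Compound 3, `Cc1cccc(C[C@H]2C(=O)OC[C@@H]2Cc2ccccc2)c1`, gives 53000 nM in a functional assay on HL-60 cells (Homo sapiens) for cytotoxicity, read by WST assay, with a stated time of 48 h (a lower number here means that less compound is needed, a higher number that more compound is needed for the effect), and stands highest of the three numbers in the set. Its nearest neighbour is compound 1, `O=C1OC[C@H](Cc2ccccc2)[C@H]1Cc1cccc(OC(F)(F)F)c1`, at 34000 nM; the step of a 1.6-fold higher number from compound 1 to compound 3 (0.19 log units; within the scatter) is within the scatter. Furthest is compound 2, `CCCCOc1cccc(C[C@H]2C(=O)OC[C@@H]2Cc2ccccc2)c1`, at 26000 nM; the step of a 2.0-fold higher number from compound 2 to compound 3 (0.31 log units; beyond the scatter) is beyond the scatter but modest. The remaining pair, a 1.3-fold lower number from compound 1 to compound 2 (0.12 log units; within the scatter), is within the scatter.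

The unmeasured compound 4, `O=C1OC[C@H](Cc2ccccc2)[C@H]1Cc1cccc(Cl)c1`, differs from compound 3 by chloro in place of methyl on an aromatic carbon. All three measured steps exchange the substituent at this same position, on an aromatic carbon meta to a large group, and none of them moves the number by more than a modest amount: trifluoromethoxy, butoxy and methyl all sit within a narrow band in this assay. Chloro itself has not been tried, so no direct precedent exists for it; the series so far suggests the position tolerates exchanges with little effect on the number.

Compound 4 is therefore expected to show a step of a 1.3-fold lower number from compound 3 to compound 4 (0.12 log units; within the scatter), small and most likely within the scatter. The estimate for compound 4 in this assay is 40000 nM, with a range of 18000 nM to 90000 nM.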

Compound 4, half-maximal effective concentration: 36000 nM
The estimate for compound 4 lay 1.1-fold (0.05 log units) above the measured number; the range from low to high includes it.
By their numbers in this assay, from the lowest: compounds 2, 1, 4 and 3 (each within the scatter of the next, the first and the last beyond it).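

Chloro on an aromatic carbon meta to a large group adds a halogen to a set that held only methyl, butoxy and trifluoromethoxy, and in this assay every new step stays within the scatter (a 1.5-fold lower number from compound 3 to compound 4 (0.17 log units; within the scatter)) (a 1.4-fold higher number from compound 2 to compound 4 (0.14 log units; within the scatter)) (a 1.1-fold higher number from compound 1 to compound 4 (0.02 log units; within the scatter)). Among the four compounds, the exchange of a single heavy atom, 3-methylphenyl to 3-chlorophenyl, therefore leaves the number where it was, and compound 4 stands within the scatter of each of the other three, so the only step printed beyond the scatter remains the modest one between butoxy and methyl (a 2.0-fold higher number from compound 2 to compound 3 (0.31 log units; beyond the scatter)). Nothing available bears on why this position takes such different groups with so little change in the number.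

The compounds shown leave open whether an amine, a carboxylic acid or a chain longer than butoxy at this same place would move the number further than any step seen here. They also leave open whether chloro would behave the same way on another carbon of the aromatic ring, or with the shared core altered.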